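The compounds below may be only part of what the source reports. "The series", "measured", "known", "first", "only" and "open" are said of these compounds alone.

Three compounds have been measured in an assay on HEK293 cells for binding affinity to 5-hydroxytryptamine receptor 7 (Homo sapiens), read by radioligand binding, tested at 1 uM; on this read-out lower numbers stand for less inhibition and higher numbers for more inhibition at the one concentration tested (going by the name of the read-out):

Compound 1 `CN1CCCN(CCn2ccc3ccc(Br)cc32)CC1` gives 93%.
Compound 2 `CN1CCCN(CCn2ccc3ccc(O)cc32)CC1` gives 28%.
Compound 3 `CN1CCCN(CCn2ccc3ccc(C(F)(F)F)cc32)CC1` gives 89%.

Compound 3 stands second highest of the three numbers: a number 4 percentage points lower from compound 1 to compound 3 (within the scatter) lies within the scatter, while a number 61 percentage points higher from compound 2 to compound 3 (beyond the scatter) is a large step. The next compound, compound 4 `C=Cc1ccc2ccn(CCN3CCCN(C)CC3)c2c1`, differs from compound 3 in one place: vinyl in place of trifluoromethyl on an aromatic carbon. For the measured compounds named here, the only comparable step is a number 4 percentage points lower from compound 1 to compound 3 (within the scatter), where one group with no hydrogen-bond donors or acceptors replaced another and nothing changed beyond the scatter. The large steps of a number 65 percentage points lower from compound 1 to compound 2 (beyond the scatter) and a number 61 percentage points higher from compound 2 to compound 3 (beyond the scatter) both involve hydroxy, which vinyl is not. A step of no size beyond the scatter is therefore expected in this assay. Compound 4 is expected to give about 85%, between 65% and 98%. The expected step is a number 4 percentage points lower from compound 3 to compound 4 (within the scatter).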

Compound 4, a percentage reported as inhibition, at one concentration (the size of the read-out at that concentration, not a potency): 79%
The estimate for compound 4 lay 6 percentage points above the measured number; the measured number falls inside the stated range.
By their numbers in this assay, from the lowest: compound 2; then compounds 4, 3 and 1 (each within the scatter of the next, the first and the last beyond it).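

In this assay, vinyl is a second group without hydrogen-bond donors or acceptors that stays close to trifluoromethyl at this aromatic carbon (a number 10 percentage points lower from compound 3 to compound 4 (within the scatter)) and far from hydroxy (a number 51 percentage points higher from compound 2 to compound 4 (beyond the scatter)). Against bromo, however, the change is modest but real (a number 14 percentage points lower from compound 1 to compound 4 (beyond the scatter)), so the groups other than hydroxy are not fully interchangeable here. Nothing available explains these differences.

On these data alone, whether a methoxy, an amine or a carboxylic acid at this aromatic carbon would fall towards hydroxy or stay with the other groups remains open.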